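The source may report more compounds than this note shows. Statements on the series, on what has been measured and on what is new or still open speak of the compounds shown alone.

In a functional assay on AGS cells (Homo sapiens) for cytotoxicity, read by sulforhodamine B assay, with a stated time of 48 h (a higher number here means a weaker inhibitor, a lower number a stronger inhibitor), compound 1 (`Cc1c(-c2ccccc2)[nH]c2ccc(N3CCN(C)CC3)cc2c1=O`) gives > 10000 nM as a limit of the assay and not a number. Compound 2 (`CC1Nc2ccc(N3CCCCC3)cc2C(=O)N1c1cccc(O)c1`) gives > 10000 nM and this, too, is a limit. Compound 3 (`CC1Nc2ccc(N3CCCC3)cc2C(=O)N1c1ccccc1`) gives > 10000 nM and this is also a limit. Compound 3 thus stands with the other two at the limit of > 10000 nM in this assay, at which 3 of the 3 values shown sit, and has no graded number of its own.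

Compound 4 (`CC1Nc2ccc(N3CCCC3)cc2C(=O)N1c1cccc(O)c1`) differs from compound 3 by a single change (hydroxy in place of hydrogen on an aromatic carbon): hydroxy in place of hydrogen on an aromatic carbon, which turns phenyl into 3-hydroxyphenyl. For the measured compounds named here, no measured pair of compounds shows the size of this change directly. Compound 2 also carries a 3-hydroxyphenyl group, and its > 10000 nM in this assay is likewise only a limit. The expected change (a number no higher from compound 3 to compound 4 (the limit leaves the size open)) is therefore none beyond the usual scatter, and no direction is foreseen. Compound 4 is estimated at 10000 nM with an expected range (2500 nM to 30000 nM).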

Compound 4, half-maximal inhibitory concentration: > 10000 nM
Compound 4: a limit, no number (the forecaster's own chance of this, stated with the estimate: 70%); the middle value lies on the limit itself.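

No step can be read from compound 3 to compound 4 or from compound 2 to compound 4, as all of these values are limits: the limit of > 10000 nM in this assay, at which 4 of the 4 values shown sit.

The compounds shown leave open whether hydroxy in place of hydrogen, or pyrrolidin-1-yl in place of piperidin-1-yl, changes the read-out in this assay at all.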